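From Nitro to Amino While the Carboxy Group Stays

A few compounds are considered here, and "the series" means these few. Any claim that something is new, unique, unknown or untested is made for them only; others in the source may bear on it.

Compound 1 `O=C(O)c1ccc([N+](=O)[O-])c(-c2nc3ccccc3n(Cc3ccccc3)c2=O)c1`: > 10000 nM
Compound 2 `O=c1c(-c2ccccc2[N+](=O)[O-])nc2ccccc2n1Cc1ccccc1`: 1000 nM
Compound 3 `O=c1c(-c2ccc(C(F)(F)F)cc2)nc2ccccc2n1Cc1ccccc1`: 1000 nM

In an assay on cells for activation of Cystic fibrosis transmembrane conductance regulator (Homo sapiens), read by fluorescence, with a stated time of 10 min (on this read-out higher numbers stand for an effect only at larger amounts of compound and lower numbers for an effect already at smaller amounts), compound 1 gives only a limit, > 10000 nM, so its exact value is not known. Compound 2, which carries the nitro group but no carboxy group, gives 1000 nM. Compound 3, with a trifluoromethyl group in place of the nitro group and likewise no carboxy group, gives 1000 nM. Among the measured compounds shown here, the one measured step, an at least 10-fold lower number from compound 1 to compound 2 (1.00 log units; beyond the scatter), shows that taking away the carboxy group lowers the number at least modestly; how far is bounded by the limit of > 10000 nM in this assay, at which 1 of the 3 values shown sits.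

Compound 4 `Nc1ccc(C(=O)O)cc1-c1nc2ccccc2n(Cc2ccccc2)c1=O` differs from compound 1 by amino in place of nitro on an aromatic carbon. The carboxy group stays. For the measured compounds named here, no measured step changes the nitro group while a carboxy group is present, so nothing here speaks directly to this change. Since compound 1 sits at a limit, the starting point itself is uncertain. With the carboxy group kept, compound 4 is expected to remain weak, a step that the limit leaves unreadable from compound 1 to compound 4. Compound 4 is therefore estimated at 15000 nM, within 3000 nM to 60000 nM, and another limit-only reading is quite possible.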

Compound 4, half-maximal effective concentration: > 10000 nM
Compound 4: a limit, no number; the forecaster's own chance of this, stated with the estimate: 60%; the middle value does not contradict the limit.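

Compound 1 and compound 4 each give only a limit in this assay, so no step between them can be read: the limit of > 10000 nM in this assay, at which 2 of the 4 values shown sit.

The compounds shown leave open whether amino in place of nitro changes the number at all while the carboxy group stays.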